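This account rests on a few compounds, and the source may have more. Where it says the series, first, only, none or still open, it means among the compounds named here.

Measured compounds in a functional assay on NCI-H1581 cells (Homo sapiens) for inhibition, read by MTT assay, with a stated time of 48 h, tested at 10 uM; a higher number here means more inhibition at the concentration tested (going by the name of the read-out), a lower number less inhibition:
compound 1 `CCc1ccc(Nc2cc(NC(=O)Nc3c(Cl)cccc3Cl)ncn2)cc1` — 38.1%
compound 2 `COc1ccc(F)cc1Nc1cc(NC(=O)Nc2c(Cl)cccc2Cl)ncn1` — 73.1%
compound 3 `CCc1cccc(Nc2cc(NC(=O)Nc3cc(OC)cc(OC)c3)ncn2)c1` — 27.7%

Compound 3 gives the lowest of the three numbers in this assay; the gap to compound 1 is beyond the scatter, and the gap to compound 2 is the largest in the set and also beyond the scatter.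

Compound 4 `COc1cc(NC(=O)Nc2cc(Nc3ccc(OC)c(I)c3)ncn2)cc(OC)c1` is not yet measured in this assay. It differs from compound 3 in one place: 3-iodo-4-methoxyphenyl in place of 3-ethylphenyl on a nitrogen on an aromatic ring.

Within the data shown here, one measured step bears on this change, since it also replaces the aryl on the same nitrogen while the rest of the molecule is kept: a number 35 percentage points higher from compound 1 to compound 2 (beyond the scatter). That step moved from an ethylphenyl to an aryl carrying a methoxy group, as the step to compound 4 does, though the urea aryl on the other side of the core is a different one in compound 3 and compound 4 than in compound 1 and compound 2, and the substitution pattern entering is not the same. Among the measured compounds shown here, an increase in this assay is therefore expected for compound 4, smaller than the one step that informs it, and with wide uncertainty: a number 17.3 percentage points higher from compound 3 to compound 4 (beyond the scatter). Compound 4 is estimated at 45%, with a range from 25% to 68%.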

Compound 4, a percentage reported as inhibition, at one concentration (the size of the read-out at that concentration, not a potency): 43%
Estimate against measurement, compound 4: 2 percentage points above, within the range that was stated.
By their numbers in this assay, from the lowest: compound 3; then compounds 1 and 4 (each within the scatter of the next); then compound 2.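

In this assay, 3-iodo-4-methoxyphenyl in place of 3-ethylphenyl on a nitrogen on an aromatic ring gives a number 15.3 percentage points higher from compound 3 to compound 4 (beyond the scatter) while the urea aryl of compound 3 is kept. Among these compounds, the aryl on this nitrogen therefore changes the read-out with a second urea aryl, not only with the one shared by compound 1 and compound 2, where the printed step is a number 35 percentage points higher from compound 1 to compound 2 (beyond the scatter) and also upward; neither of these two steps goes against that direction, though they bring in different aryl groups and rest on different urea partners. No evidence is available on why the new aryl group raises the number in this series.

The compounds shown do not separate the iodine from the methoxy within 3-iodo-4-methoxyphenyl, and they do not show what 5-fluoro-2-methoxyphenyl would give with the urea aryl of compound 3. Going by these compounds, how an aryl carrying an amine or a carboxylic acid would read at this nitrogen in this assay also remains open.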